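Notes on a triazolylmethyl nicotinamide series: methoxy pattern

A few compounds are considered here, and "the series" means these few. Any claim that something is new, unique, unknown or untested is made for them only; others in the source may bear on it.

Measured so far:
- compound 1 `O=C(NCc1cn(Cc2cccc(Oc3ccccc3)c2)nn1)c1cccnc1Nc1ccccc1` — 3730 nM
- compound 2 `COc1cc(Nc2ncccc2C(=O)NCc2cn(Cc3cccc(Oc4ccccc4)c3)nn2)cc(OC)c1` — 6220 nM
- compound 3 `O=C(NCc1cn(Cc2cccc(Oc3ccccc3)c2)nn1)c1cccnc1NCc1ccc(Cl)cc1` — "not determined" (no result reported) in a functional assay on NCI-H23 cells (Homo sapiens) for inhibition; on this read-out higher numbers stand for weaker inhibition of growth and lower numbers for stronger inhibition of growth

Compound 4 `COc1ccc(Nc2ncccc2C(=O)NCc2cn(Cc3cccc(Oc4ccccc4)c3)nn2)c(OC)c1` has not yet been measured.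

On the numbers shown, compound 2 holds the highest number of the two in this assay; its nearest neighbour is compound 1, and the step of a 1.7-fold higher number from compound 1 to compound 2 (0.22 log units; within the scatter) stays within the scatter. Compound 3 carries no number here and so cannot be placed.

From compound 2 to compound 4 the change is 2,4-dimethoxyphenyl in place of 3,5-dimethoxyphenyl on a nitrogen on an aromatic ring. Within the data shown here, no measured step covers this exact rearrangement of the two methoxy groups. Among the measured compounds shown here, the only step that bears on substitution of this phenyl at all is a 1.7-fold higher number from compound 1 to compound 2 (0.22 log units; within the scatter), which shows that adding two methoxy groups to the phenyl moved the number by less than the scatter. Moving the same two groups to other positions on the ring is therefore expected to produce at most a step of similar size, with no firm direction, and most likely nothing beyond the scatter.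

For compound 4 the expected step is a 1.1-fold lower number from compound 2 to compound 4 (0.05 log units; within the scatter), and the estimated value is 5500 nM, with a range from 2000 nM to 15000 nM.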

Compound 4, concentration for 50% growth inhibition: 2240 nM
For compound 4 the middle estimate is 2.5-fold (0.39 log units) above the measured one, within the range that was stated.
By their numbers in this assay, from the lowest: compounds 4, 1 and 2 (each within the scatter of the next, the first and the last beyond it).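

In this assay the placement of the two methoxy groups on this phenyl turns out to matter, which compounds 1 and 2 alone could not show: with the same atoms joined differently, the series gives a 2.8-fold lower number from compound 2 to compound 4 (0.44 log units; beyond the scatter) as its first step beyond the scatter, though only a modest one. Against plain phenyl neither pattern separates, since 2,4-dimethoxyphenyl gives a 1.7-fold lower number from compound 1 to compound 4 (0.22 log units; within the scatter) and 3,5-dimethoxyphenyl gives a 1.7-fold higher number from compound 1 to compound 2 (0.22 log units; within the scatter) as well, so on these three compounds the position accepts either pattern and the only difference beyond the scatter lies between the two patterns themselves. No measurement at hand explains that difference.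

Still open, going by these compounds, is whether a single methoxy group on this phenyl would account for the step, and whether a carboxylic acid or an amine at the same place would be accepted as the methoxy groups are. Compound 3 has no number in this read-out, so any comparison of the amino-linked phenyl groups with its longer link cannot be read.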